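The source may report more compounds than this note shows. Statements on the series, on what has been measured and on what is new or still open speak of the compounds shown alone.

So far two compounds have numbers in a functional assay on U-87MG ATCC cells (Homo sapiens) for cytotoxicity, read by MTT assay, with a stated time of 48 h; a higher number here means a weaker inhibitor, a lower number a stronger inhibitor. Compound 1 `C/C(=N\NC(=S)Nc1ccccc1Cl)c1ccccn1` gives 2.6 nM, and compound 2 `C/C(=N/NC(=S)Nc1cccc(I)c1)c1ccccn1` gives 84 nM. Compound 1 therefore holds the lower of the two numbers, and the gap lies beyond the usual scatter of repeated measurements. These two compounds do not differ in just one place, so no single structural change can be read from their gap. Compound 3 `C/C(=N\NC(=S)Nc1ccccc1[N+](=O)[O-])c1ccccn1` does differ from compound 1 in one place: nitro in place of chloro on an aromatic carbon. For the measured compounds named here, with no measured step to guide the forecast, it can lean only on the spread of the two numbers. Compound 1 at 2.6 nM sits at the low end, and compound 2 at 84 nM shows how much higher a number can lie among these compounds. A moderate rise is therefore expected rather than a further fall, and the expected step is a 3.8-fold higher number from compound 1 to compound 3 (0.59 log units; beyond the scatter). The estimated value for compound 3 is 10 nM, with an expected range from 1.5 nM to 70 nM.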

Compound 3, half-maximal inhibitory concentration: 4.3 nM
Compound 3: middle estimate off by 2.3-fold (0.37 log units), on the high side; the measured number falls inside the stated range.
By their numbers in this assay, from the lowest: compounds 1 and 3 (each within the scatter of the next); then compound 2.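

In this assay, nitro in place of chloro, ortho to a large group on the carbon-only aromatic ring, gives a 1.7-fold higher number from compound 1 to compound 3 (0.22 log units; within the scatter), so the two compounds cannot be told apart in this assay. For the compounds shown here, this is the first single change that can be read, and it shows that the low number of compound 1 does not depend on keeping a chlorine atom at this position, even though nitro has more heavy atoms and brings hydrogen-bond acceptors that chloro lacks. No measurement here explains why these two different groups give such similar numbers.

The compounds shown leave open how far this tolerance extends, since only chloro and nitro can be compared at this position, and an amine, a carboxylic acid, a methoxy group or a plain hydrogen could give a very different number. They also leave open what moving a group to another ring carbon does on its own, as compound 2 differs from compound 1 in more than one place.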